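Working notes: from compound 1 toward compound 4

The source may report more compounds than this note shows. Statements on the series, on what has been measured and on what is new or still open speak of the compounds shown alone.

Measured compounds:
compound 1 `CC(C)c1ccc(/C=C/C(=O)c2ccc(OCC(=O)N[C@H]3CCOC3=O)cc2)cc1`: 4660 nM
compound 2 `O=C1OCC[C@@H]1NC(=S)SCCOc1ccccc1`: > 64000 nM, a limit
compound 3 `O=C1OCC[C@@H]1NC(=S)SCCOc1ccccc1Cc1ccccc1`: > 64000 nM, a limit

Among the compounds with values here, in a functional assay on PC-3 cells (Homo sapiens) for antiproliferative activity, read by MTT assay, with a stated time of 72 h (on this read-out lower numbers stand for stronger inhibition and higher numbers for weaker inhibition), compound 1 gives 4660 nM, the only number in the set. The other two entries are limits rather than numbers: the limit of > 64000 nM in this assay, at which 2 of the 3 values shown sit. Within the data shown here, the single step between measured compounds, a step that the two limits leave unreadable from compound 2 to compound 3, is unreadable and concerns a scaffold unlike that of compound 1, so it says nothing about aryl replacement.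

Compound 4 `O=C(COc1ccc(C(=O)/C=C/c2ccc(F)c(F)c2)cc1)N[C@H]1CCOC1=O` differs from compound 1 by 3,4-difluorophenyl in place of 4-isopropylphenyl on a double-bonded chain carbon bound to a double-bonded chain carbon. Among the measured compounds shown here, no measured step touches this position, so no shift beyond the scatter is expected. For compound 4 the expected step is a 1.2-fold higher number from compound 1 to compound 4 (0.07 log units; within the scatter). Compound 4 is estimated at 5500 nM, with a range from 1500 nM to 20000 nM.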

Compound 4, half-maximal inhibitory concentration: 21900 nM
Compound 4: the middle estimate sits 4.0-fold (0.60 log units) below what was measured, outside the stated range (above it).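

In this assay, within the data shown here, 3,4-difluorophenyl in place of 4-isopropylphenyl gives a 4.7-fold higher number from compound 1 to compound 4 (0.67 log units; beyond the scatter), so this position responds to a change of aryl group, which no earlier compound could show. Compound 4 still gives a number rather than a limit, so the change weakens the result without taking it out of readable range: the limit of > 64000 nM in this assay, at which 2 of the 4 values shown sit.

Loss of the isopropyl group and entry of the two fluorines come together in this one step, and the data do not separate them. Going by these compounds, whether a dimethylamino or carboxylic acid group on the phenyl ring would be tolerated here remains open.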